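Exocyclic substituent swap on the oxazolidinedione series

The source may report more compounds than this note shows. Statements on the series, on what has been measured and on what is new or still open speak of the compounds shown alone.

Measured so far:
- compound 1 `CCC(CC)C(/C=C1\OC(=O)NC1=O)c1ccc(-c2ccc3cccc(F)c3c2)[nH]c1=O`: 23 nM
- compound 2 `CC(C)/C(=C1/OC(=O)NC1=O)c1ccc(-c2ccc3cccc(F)c3c2)[nH]c1=O`: 1300 nM

In a functional assay on CHO cells for antagonist activity at prostaglandin E2 receptor EP3 subtype (Homo sapiens), read by cAMP accumulation, with a stated time of 30 min (a lower number here means a stronger inhibitor, a higher number a weaker inhibitor), compound 1 gives 23 nM and is the lowest of the two numbers recorded. Going by the values given here, compound 2 gives 1300 nM in this assay, a markedly higher number that lies beyond the scatter; the two compounds differ in more than one place, so no single step connects them.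

Compound 3 `O=C1NC(=O)/C(=C/C(c2ccccc2)c2ccc(-c3ccc4cccc(F)c4c3)[nH]c2=O)O1` has not yet been measured in this assay. It is derived from compound 1 by the change (phenyl in place of pentan-3-yl on a saturated chain carbon bound to an aromatic carbon and a double-bonded chain carbon). Among the compounds with values here, no measured pair shows a comparable exchange, so the size of the step rests on judgement. A modest shift toward a higher number is expected, possibly within the scatter, expressed as a 2.2-fold higher number from compound 1 to compound 3 (0.34 log units; beyond the scatter). Compound 3 is estimated at 50 nM in this assay, with a likely range from 10 nM to 300 nM.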

Compound 3, half-maximal inhibitory concentration: 190 nM
Compound 3: middle estimate off by 3.8-fold (0.58 log units), on the low side; the measured number falls inside the stated range.
By their numbers in this assay, from the lowest: compound 1; then compound 3; then compound 2.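

In this assay, phenyl in place of pentan-3-yl on a saturated chain carbon bound to an aromatic carbon and a double-bonded chain carbon gives an 8.3-fold higher number from compound 1 to compound 3 (0.92 log units; beyond the scatter), with the rest of the core of compound 1 unchanged. Going by these compounds alone, this is the first single-place step; it shows that the number responds to the group at this carbon, and that inhibition is reduced but not lost, with compound 3 at 190 nM. No measurement shown here accounts for the step, so its origin stays unassigned.

Still open, as far as these compounds go, is whether a cyclohexyl group at this carbon would read closer to compound 1 or to compound 3, which would separate the presence of a ring from its aromatic character. A single exchange at one position supports no trend, so a smaller ethyl group or a pyridyl ring could not be placed from these data.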